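Acetyl to methoxycarbonyl on the side-chain nitrogen

The source may hold more compounds than are shown below. What is called first, only, known or untested is meant among the compounds shown, and "the series" means these compounds.

Two members of the series are measured. Compound 1 `CCCCCCCCN1C(=O)[C@H](Cc2ccc(-c3cccc(CN(CCCC)C(=O)NC)c3)cc2)N(C)C(=O)[C@@H]1C` gives 1.2 nM in a functional assay for agonist activity at follicle-stimulating hormone receptor (Homo sapiens), read by a luciferase reporter; a lower number here means that less compound is needed, a higher number that more compound is needed for the effect; compound 2 `CCCCCCCCN1C(=O)[C@H](Cc2ccc(-c3cccc(CN(COC)C(C)=O)c3)cc2)N(C)C(=O)[C@@H]1C` gives 9.7 nM, the highest of the two numbers, after the step of an 8.1-fold higher number from compound 1 to compound 2 (0.91 log units; beyond the scatter). Compound 3 `CCCCCCCCN1C(=O)[C@H](Cc2ccc(-c3cccc(CN(COC)C(=O)OC)c3)cc2)N(C)C(=O)[C@@H]1C` carries the change (methoxy in place of methyl on a carbonyl carbon). Within the data shown here, no measured step alters the carbonyl substituent alone, so the one known step only sets the scale of what this side chain can do, and a change of this kind is expected to stay near the scatter: a 1.0-fold higher number from compound 2 to compound 3 (0.01 log units; within the scatter). Compound 3 is therefore estimated at 10 nM, between 3 nM and 35 nM.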

Compound 3, half-maximal effective concentration: 1.8 nM
For compound 3 the middle estimate is 5.6-fold (0.74 log units) above the measured one; measured number outside the range, below it.
By their numbers in this assay, from the lowest: compounds 1 and 3 (each within the scatter of the next); then compound 2.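

In this assay, the carbonyl substituent on the side-chain nitrogen proves to matter on its own: methoxy in place of methyl on this carbonyl carbon gives a 5.4-fold lower number from compound 2 to compound 3 (0.73 log units; beyond the scatter). The exchange of the whole group, (methoxycarbonyl)(methoxymethyl)amino in place of butyl(methylcarbamoyl)amino, gives a 1.5-fold higher number from compound 1 to compound 3 (0.18 log units; within the scatter), so the side chains of these two compounds are not told apart here. No supporting data bear on the size of the methoxy step. Open, from the compounds shown here alone, is whether ethoxy or dimethylamino on the same carbonyl carbon would keep the number of compound 3.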